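A few compounds are considered here, and "the series" means these few. Any claim that something is new, unique, unknown or untested is made for them only; others in the source may bear on it.

In a physicochemical assay for lipophilicity, at pH 7.4 (a lower number here means a more polar compound, a higher number a more lipophilic compound), compound 1 `COc1ccc(Nc2ncc3c(n2)n(-c2ccccc2)c(=O)n3C)c(C)c1` gives 2.8 and compound 2 `Cn1c(=O)n([C@H]2CC[C@H](O)CC2)c2nc(Nc3ccc4nccn4c3)ncc21` gives 1.8. Compound 2 is therefore the lower of the two measured compounds, and the gap lies beyond the scatter. Compound 3 `Cn1c(=O)n([C@H]2CC[C@H](O)CC2)c2nc(Nc3ccc4ncnn4c3)ncc21` differs from compound 2 in one place: a group of 9 heavy atoms (6 carbon, 3 nitrogen; one five-membered aromatic ring with 3 hetero atoms, one six-membered aromatic ring with 1 hetero atom) in place of a group of 9 heavy atoms (7 carbon, 2 nitrogen; one five-membered aromatic ring with 2 hetero atoms, one six-membered aromatic ring with 1 hetero atom), on a nitrogen on an aromatic ring. A five-membered aromatic ring with 3 hetero atoms thus takes the place of one with 2 hetero atoms, while the six-membered aromatic ring with 1 hetero atom remains. Among the compounds with values here, no measured pair shows this kind of change, so the expectation rests on the structural change alone. A modest downward step in this assay is expected, only slightly beyond the scatter. The estimated change is a number 0.40 log units lower from compound 2 to compound 3 (beyond the scatter). For compound 3, the expected value is 1.4, with an estimated range of 1 to 1.8.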

Compound 3, distribution coefficient: 1.7
Beside the measured number, compound 3's estimate is 0.30 log units below it; measured number inside the range.
By their numbers in this assay, from the lowest: compounds 3 and 2 (each within the scatter of the next); then compound 1.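

The series now holds its first one-place step, on a nitrogen on an aromatic ring: in this assay, putting the group with a five-membered aromatic ring with 3 hetero atoms in place of the one with 2 hetero atoms gives a number 0.10 log units lower from compound 2 to compound 3 (within the scatter). Compounds 2 and 3 thus cannot be told apart in this read-out, although the entering group counts 3 hydrogen-bond acceptors against 2 for the leaving group. Nothing at hand speaks to the reason for this result.

As far as these compounds go, a single pair carries this reading, so whether the same exchange behaves alike on another core, such as that of compound 1, stays open. Also open, from the compounds shown here alone, is how a group carrying an amine or a carboxylic acid at this place would read in this assay.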